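The source may hold more compounds than are shown below. What is called first, only, known or untested is meant among the compounds shown, and "the series" means these compounds.

Three compounds built on one shared core were tested for their effect on the growth of a human liver cell line, and all three sit at the edge of what the test can report. Compound 1 `COc1ccc(NC(=O)/C=C/c2coc3cc(OC)ccc3c2=O)cc1` carries a methoxy group on the core and a 4-methoxyphenyl on the amide nitrogen. In a functional assay on L02 cells (Homo sapiens) for inhibition, read by MTT assay, with a stated time of 48 h (on this read-out higher numbers stand for weaker inhibition and lower numbers for stronger inhibition), compound 1 gives > 200000 nM, which is a limit of the test rather than a number. Compound 2 `COc1ccc(NC(=O)/C=C/c2coc3cc(O)ccc3c2=O)cc1` differs from compound 1 in that the methoxy oxygen carries a hydrogen instead of a methyl. In this assay compound 2 gives > 200000 nM, again a limit. Compound 3 `Cc1ccccc1NC(=O)/C=C/c1coc2cc(O)ccc2c1=O` keeps the hydroxy group of compound 2 but bears a 2-methylphenyl on the amide nitrogen. In this assay compound 3 gives > 200000 nM, also a limit.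

The change from compound 2 to compound 1 is methyl in place of hydrogen on an oxygen on an aromatic ring; the step it made is a step that the two limits leave unreadable from compound 2 to compound 1. The change from compound 2 to compound 3 is 2-methylphenyl in place of 4-methoxyphenyl on an amide-type nitrogen, and its step is a step that the two limits leave unreadable from compound 2 to compound 3. Both steps are unreadable because of the limit of > 200000 nM in this assay, at which 3 of the 3 values shown sit.

Compound 4 `COc1ccc2c(=O)c(/C=C/C(=O)Nc3ccccc3C)coc2c1` is not yet measured. It differs from compound 3 by methyl in place of hydrogen on an oxygen on an aromatic ring, the same change as that from compound 2 to compound 1, at the same place on the core. Since compound 3 shows only a limit, > 200000 nM, and the same change from compound 2 to compound 1 left both partners at the limit, compound 4 is expected to stay there too, and the expected step is a step that the limit leaves unreadable from compound 3 to compound 4. The estimate for compound 4 in this assay is 300000 nM, with a range from 100000 nM to 1000000 nM.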

Compound 4, half-maximal inhibitory concentration: > 200000 nM
Compound 4 ended at the assay's limit (the forecaster's own chance of this, stated with the estimate: 85%); the middle value is on the limit's open side.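

No new step can be read between compound 3 and compound 4 or between compound 1 and compound 4, because all the compounds share one limit: the limit of > 200000 nM in this assay, at which 4 of the 4 values shown sit. The compounds shown leave open whether hydroxy or methoxy on the core, or 2-methylphenyl or 4-methoxyphenyl on the amide nitrogen, makes any difference in this assay, and how strongly, if at all, any of these four compounds inhibits.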